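Urea series: hydroxy for amino, cytotoxicity outlook

The source may hold more compounds than are shown below. What is called first, only, known or untested is meant among the compounds shown, and "the series" means these compounds.

The series is read in an ADME assay on HEK293 cells (Homo sapiens) for cytotoxicity, with a stated time of 72 h; on this read-out lower numbers stand for an effect already at smaller amounts and higher numbers for an effect only at larger amounts of compound. Compound 1 `Cc1cc(NC(=O)Nc2ccc(C)c(Cl)c2)c2ccccc2n1` gives in this assay only the limit > 25000 nM and no number. Compound 2 `COc1ccc(NC(=O)Nc2cc(C)nc3ccccc23)cc1F` likewise reaches only the limit > 25000 nM. Compound 3 `Cc1cc(NC(=O)Nc2ccc(N)cc2)c2ccccc2n1` also stands at the limit > 25000 nM, again not a measured number. Among the measured compounds shown here, compound 3 therefore sits where the whole set sits: every value shown is a limit, as summed up by the limit of > 25000 nM in this assay, at which 3 of the 3 values shown sit; no ordering among the three compounds can be drawn, and no measured step between any two of them exists.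

Compound 4 `Cc1cc(NC(=O)Nc2ccc(O)cc2)c2ccccc2n1` differs from compound 3 in one place: hydroxy in place of amino on an aromatic carbon. For the measured compounds named here, with no measured step in the set and all three values at the same limit, nothing in the data points toward a shift in either direction; the step that the limit leaves unreadable from compound 3 to compound 4 is estimated as none beyond the scatter. Compound 4 is accordingly expected to give 40000 nM in this assay, within a range from 15000 nM to 120000 nM, and most probably to be reported once more only as a limit.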

Compound 4, half-maximal effective concentration: > 25000 nM
Compound 4 ended at the assay's limit; the forecaster's own chance of this, stated with the estimate: 85%; the middle value lies beyond the limit too.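

Compound 4, like compound 3, stands only at a limit in this assay, so no step can be read between the two. The compounds shown leave open whether any of them has a measurable half-maximal effect in this assay, and how they would rank: the limit of > 25000 nM in this assay, at which 4 of the 4 values shown sit.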